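The source may report more compounds than this note shows. Statements on the series, on what has been measured and on what is new or still open speak of the compounds shown alone.

Measured so far:
compound 1 `C[C@H](c1ccccc1)N1C(=O)O[C@](Cc2ccccc2)(c2nc(-c3ccccc3)co2)C1=O` — 15%
compound 2 `C[C@H](c1ccccc1)N1C(=O)O[C@](Cc2ccccc2)(c2ncc(-c3ccccc3)[nH]2)C1=O` — 4%

Both compounds were run in an ADME assay (liver) for metabolic stability, with Liver microsome (Rattus norvegicus) as the target, using microsomes, with a stated time of 0.5 h, tested at 1 uM; a lower number here means that less of the compound is left, a higher number that more of the compound is left. Among the measured compounds shown here, compound 2 stands lowest of the two numbers; the only neighbour is compound 1, and the single measured step is a number 11 percentage points lower from compound 1 to compound 2 (beyond the scatter), a modest change that lies beyond the scatter. That step exchanged one five-membered aromatic ring for another on the saturated ring carbon of the shared core.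

Compound 3 `C[C@H](c1ccccc1)N1C(=O)O[C@](Cc2ccccc2)(c2nnc(-c3ccccc3)[nH]2)C1=O` carries the change (5-phenyl-4H-1,2,4-triazol-3-yl in place of 5-phenyl-1H-imidazol-2-yl on a saturated ring carbon). It is the same kind of exchange — one five-membered aromatic ring with a phenyl group for another on the same saturated carbon — so the step from compound 1 to compound 2 is the only measured one that bears on it. That step moved the read-out by a modest amount, and compound 2 already sits close to the bottom of the scale, so little room remains downward. The expected step is therefore a number 1 percentage points higher from compound 2 to compound 3 (within the scatter), within the scatter, and the estimate for compound 3 in this assay is 5%, with a range from 1% to 15%.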

Compound 3, percent of the compound remaining: 29%
Compound 3: the middle estimate sits 24 percentage points below what was measured; the measured number lies above the stated range.
By their numbers in this assay, from the lowest: compound 2; then compound 1; then compound 3.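

In this assay, the exchange on the saturated ring carbon gives a number 25 percentage points higher from compound 2 to compound 3 (beyond the scatter), so changing the five-membered aromatic ring at this position can raise the read-out as well as lower it, whereas the earlier step ran downward only. The 5-phenyl-4H-1,2,4-triazol-3-yl group, whose five-membered ring has 3 hetero atoms, also compares favourably with the 4-phenyl-1,3-oxazol-2-yl group, with a number 14 percentage points higher from compound 1 to compound 3 (beyond the scatter), so among the three rings shown it leaves the most compound remaining, and both of its steps are printed as beyond the scatter. No supporting measurement bears on why these rings differ, so the result stands as an observation for this series alone.

The compounds shown leave open whether the higher number depends on the hydrogen on the triazole ring nitrogen, which a methyl group at that nitrogen would test. They also leave open whether the gain survives on the phenyl group of the triazole being replaced by a pyridine ring, or on the benzyl group or the 1-phenylethyl group elsewhere on the shared core being changed.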